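This account rests on a few compounds, and the source may have more. Where it says the series, first, only, none or still open, it means among the compounds named here.

Measured so far in a functional assay on MCF7 cells (Homo sapiens) for cytotoxicity, read by sulforhodamine B assay; on this read-out lower numbers stand for stronger inhibition of growth and higher numbers for weaker inhibition of growth 
Compound 1 `CC1=CC[C@@H]([C@@](C)(O)CCCC(C)(C)NC=S)CC1` gives 16000 nM 
Compound 2 `COc1ccc(/C=N\NC(=S)NC(C)(C)CCC[C@](C)(O)[C@@H]2CC=C(C)CC2)cc1` gives 6500 nM

Compound 2 holds the lower of these two numbers, and the gap up to compound 1 lies beyond the usual scatter. These two compounds differ in more than one place, so no single change has yet been measured on its own.

Compound 3 `CC1=CC[C@@H]([C@@](C)(O)CCCC(C)(C)NC(=S)N/N=C\c2cccc([N+](=O)[O-])c2)CC1` differs from compound 2 by one change 3-nitrophenyl in place of 4-methoxyphenyl on a carbon with a double bond to nitrogen that puts 3-nitrophenyl in place of 4-methoxyphenyl on a carbon with a double bond to nitrogen. With no measured swap of this kind to draw on, the expectation starts from compound 2 at 6500 nM as the nearest reference. In this assay no step beyond the scatter is expected in either direction. The estimated step of a 1.1-fold lower number from compound 2 to compound 3 (0.03 log units; within the scatter) is expected to stay small. For compound 3 the estimate is 6000 nM with an expected range from 2200 nM to 16000 nM once it is measured.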

Compound 3, concentration for 50% growth inhibition: 6720 nM
For compound 3 the middle estimate is 1.1-fold (0.05 log units) below the measured one; the range from low to high includes it.
By their numbers in this assay, from the lowest: compounds 2 and 3 (each within the scatter of the next); then compound 1.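

In this assay, within the data shown here, swapping 3-nitrophenyl in for 4-methoxyphenyl on a carbon with a double bond to nitrogen gives a 1.0-fold higher number from compound 2 to compound 3 (0.01 log units; within the scatter), the only change so far that can be read on its own. Two differently substituted phenyl groups therefore read alike at this position, and this read-out does not separate them. No measured information explains this match.

From the compounds shown here alone, whether the position accepts other kinds of group, such as an amine, a carboxylic acid or an unsubstituted phenyl, remains open. Also open, going by these compounds, is what the phenyl-bearing part adds on its own, as compound 1 differs from compound 2 in more than one place, so their gap cannot be tied to a single change.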